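Ring-Closing the Amine: From Compound 1 to Compound 3

The source may report more compounds than this note shows. Statements on the series, on what has been measured and on what is new or still open speak of the compounds shown alone.

Measured compounds:
- compound 1, `C#CCN(CCCC)Cc1cn(-c2cc(NC(=S)NCC)ncn2)cn1`, 2.43% in an assay on isolated protein for inhibition of Amine oxidase [flavin-containing] A (Homo sapiens), read by fluorescence and Amplex Red, with a stated time of 15 min, tested at 50 uM; a lower number here means less inhibition, a higher number more inhibition at the concentration tested (going by the name of the read-out)
- compound 2, `C#CCN(Cc1ccccc1)Cc1cn(-c2cc(NC(=S)NCC)ncn2)cn1`, 17.8% in this assay

Compound 1 stands lowest of the two numbers in this assay; its nearest neighbour is compound 2, which lies a number 15.4 percentage points higher from compound 1 to compound 2 (beyond the scatter), a change brought by phenyl in place of propyl on a saturated chain carbon bound to an amine nitrogen.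

Compound 3, `C#CCN1CCN(Cc2cn(-c3cc(NC(=S)NCC)ncn3)cn2)CC1`, is not yet measured. It differs from compound 1 by a group of 9 heavy atoms (7 carbon, 2 nitrogen; one six-membered non-aromatic ring with 2 hetero atoms) in place of a group of 8 heavy atoms (7 carbon, 1 nitrogen; no ring), on a saturated chain carbon bound to an aromatic carbon. The open-chain amine that carries the propargyl group is thereby folded into a 4-propargylpiperazin-1-yl ring.

Among the measured compounds shown here, no measured step covers this kind of change. For the measured compounds named here, the only step available, the one from compound 1 to compound 2, swaps a propyl for a phenyl and is modest in size; it does not tell how closing the amine into a piperazine ring will behave. Since compound 1 shows almost no inhibition, the expectation is a number in the same low region, with no step beyond the scatter in this assay.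

Compound 3 is therefore estimated at 5%, with a range from -5% to 20%. This estimate means a step of a number 2.6 percentage points higher from compound 1 to compound 3 (within the scatter), expected to stay within the scatter.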

Compound 3, a percentage reported as inhibition, at one concentration (the size of the read-out at that concentration, not a potency): 9.22%
Compound 3: the middle estimate sits 4.2 percentage points below what was measured; the measured number falls inside the stated range.
By their numbers in this assay, from the lowest: compounds 1, 3 and 2 (each within the scatter of the next, the first and the last beyond it).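

Folding the open-chain amine of compound 1 into a 4-propargylpiperazin-1-yl ring, on a saturated chain carbon bound to an aromatic carbon, gives a number 6.8 percentage points higher from compound 1 to compound 3 (within the scatter) in this assay, so at this position a ring holding a second nitrogen can take the place of the open chain with no step that stands clear of the usual scatter. The earlier pair showed only what a swap on the open chain can do, with phenyl in place of propyl giving a number 15.4 percentage points higher from compound 1 to compound 2 (beyond the scatter), whereas this change rebuilds the amine itself, and a reading at a single concentration like this one still says nothing about potency. Nothing available explains why this ring change gives so small a step.

The compounds shown leave open whether the ring or its second nitrogen matters more, a question that a piperidine or a morpholine ring in the same place could help to separate. They also leave open what the propargyl group contributes on the ring, which a 4-methylpiperazin-1-yl group at this position could begin to address.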